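A few compounds are considered here, and "the series" means these few. Any claim that something is new, unique, unknown or untested is made for them only; others in the source may bear on it.

Working notes on the series. Of the compounds shown here, two have been measured in a toxicity assay on HeLa cells (Homo sapiens) for cytotoxicity, read by MTT assay, with a stated time of 24 h; on this read-out lower numbers stand for stronger inhibition and higher numbers for weaker inhibition. Compound 1, `Cc1ncc([N+](=O)[O-])n1CC(O)CSC(=S)N1CCN(c2ccccc2)CC1`, gives only a limit of the assay, > 5000000 nM, in this assay. Compound 2, `CCOC(=O)N1CCN(C(=S)SCC(O)Cn2cc([N+](=O)[O-])nc2C)CC1`, is the one compound with a number in this assay, 2360000 nM, and that number is the only one shown. The other value shown, that of compound 1, is a limit (the limit of > 5000000 nM in this assay, at which 1 of the 2 values shown sits).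

Compound 3, `Cc1nc([N+](=O)[O-])cn1CC(O)CSC(=S)N1CCN(c2ccccc2)CC1`, has not been measured. It differs from compound 2 by one change: phenyl in place of ethoxycarbonyl on an amine nitrogen in a ring. Among the compounds with values here, no measured pair gives the size of this step directly. Compound 1 carries phenyl on an amine nitrogen in a ring as well and reaches only a limit of the assay, > 5000000 nM, in this assay.

On that basis the step from compound 2 to compound 3 is expected to go toward weaker inhibition and to reach beyond the usual scatter, a 2.1-fold higher number from compound 2 to compound 3 (0.33 log units; beyond the scatter). For compound 3 the estimate in this assay is 5000000 nM, within 2000000 nM to 15000000 nM, with a fair chance that only a limit is reported.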

Compound 3, half-maximal inhibitory concentration: > 5000000 nM
Compound 3 was reported as a limit (the forecaster's own chance of this, stated with the estimate: 55%); the middle value lies on the limit itself.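

Within the data shown here, replacing ethoxycarbonyl with phenyl on an amine nitrogen in a ring gives the first readable step at this position in this assay, an at least 2.1-fold higher number from compound 2 to compound 3 (0.32 log units; beyond the scatter), and this step marks only the smallest change the data allow. Among the compounds shown, a number rather than a limit appears only with ethoxycarbonyl at this position, in compound 2. Compound 1 and compound 3, both carrying phenyl on this nitrogen, each give a limit of the assay, so the step between them, 2-methyl-4-nitro-1H-imidazol-1-yl in place of 2-methyl-5-nitro-1H-imidazol-1-yl, cannot be read: the limit of > 5000000 nM in this assay, at which 2 of the 3 values shown sit.

The compounds shown leave open how far the number rises with phenyl, and whether another group on this nitrogen, such as acetyl, benzyl or a longer alkoxycarbonyl chain, keeps a number within the range of the assay. Also open, going by these compounds, is whether 2-methyl-5-nitro-1H-imidazol-1-yl paired with ethoxycarbonyl gives a number that could be set against compound 2, which would make the change between the two nitroimidazole groups readable.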